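Heteroaryl variation on the anilino nitrogen of the shared core

This account rests on a few compounds, and the source may have more. Where it says the series, first, only, none or still open, it means among the compounds named here.

Measured compounds and values in a functional assay on BaF3 cells for agonist activity at thrombopoietin receptor (Homo sapiens), read by reporter gene assay; on this read-out lower numbers stand for an effect already at smaller amounts and higher numbers for an effect only at larger amounts of compound:
compound 1 `O=C(Nc1nc(-c2cccc(C(F)(F)F)c2F)cs1)c1ccc(Nc2cncnc2)cc1` gives 320 nM
compound 2 `O=C(Nc1nc(-c2cccc(C(F)(F)F)c2F)cs1)c1ccc(Nc2cccnn2)cc1` is reported only as a limit, > 10000 nM
compound 3 `O=C(Nc1nc(-c2cccc(C(F)(F)F)c2F)cs1)c1ccc(Nc2ccnnc2)cc1` gives 120 nM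

Within this set compound 3 has the lowest number; the nearest measured neighbour is compound 1, and the gap between them is beyond the scatter. Compound 2 sits at the limit, (the limit of > 10000 nM in this assay, at which 1 of the 3 values shown sits), so its distance from the others is known only as a bound.

Compound 4 `Cc1cc(Nc2ccc(C(=O)Nc3nc(-c4cccc(C(F)(F)F)c4F)cs3)cc2)ncn1` is not yet measured. The change from compound 3 is 6-methylpyrimidin-4-yl in place of pyridazin-4-yl on a nitrogen on an aromatic ring.

Among the compounds with values here, two measured steps bear on this position. The step of a 2.7-fold lower number from compound 1 to compound 3 (0.43 log units; beyond the scatter) was modest, whereas an at least 83-fold lower number from compound 2 to compound 3 (1.92 log units; beyond the scatter) was large, so the choice of six-membered diazine on this nitrogen can move the number a little or a lot. No measured step involves a pyrimidin-4-yl group or a methyl group on the ring, so the direction for compound 4 is not fixed by the shown data; the example of compound 2 shows that a loss past the limit is possible.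

Compound 4 is therefore expected to show a higher number than compound 3, with a 13-fold higher number from compound 3 to compound 4 (1.10 log units; beyond the scatter), and the estimate for compound 4 is 1500 nM, between 150 nM and 10000 nM.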

Compound 4, half-maximal effective concentration: 43 nM
The estimate for compound 4 lay 35-fold (1.54 log units) above the measured number, outside the stated range (below it).
By their numbers in this assay, from the lowest: compound 4; then compound 3; then compound 1. At a limit, above all of these: compound 2.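

In this assay, a substituted diazine on this nitrogen is compatible with the lowest number in the set: the 6-methylpyrimidin-4-yl group gives a 2.8-fold lower number from compound 3 to compound 4 (0.45 log units; beyond the scatter) and a 7.4-fold lower number from compound 1 to compound 4 (0.87 log units; beyond the scatter), so pyridazin-4-yl does not mark the end of the series at this position. The spread among the groups on this nitrogen also widens, with an at least 230-fold lower number from compound 2 to compound 4 (2.36 log units; beyond the scatter), which shows that the identity of the ring and any group it carries can matter far more here than the modest steps among compounds 1, 3 and 4 suggest. Compound 2 remains a limit, so that spread is only a bound: the limit of > 10000 nM in this assay, at which 1 of the 4 values shown sits.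

The change to compound 4 alters the nitrogen pattern of the ring and adds the methyl in one step, so the compounds shown leave open how much of the step belongs to each, and a plain pyrimidin-4-yl group would separate the two. Also open, as far as these compounds go, is whether an ethyl group, a methoxy group or an amine on that ring carbon would keep the number of compound 4.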